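The source may hold more compounds than are shown below. What is called first, only, known or untested is meant among the compounds shown, and "the series" means these compounds.

Of the compounds shown here, two from this series have been tested so far. Compound 1 `COC(=O)c1ccc(C)cc1OC(=O)COc1cc(O)c2c(=O)cc(-c3ccccc3)oc2c1` and compound 2 `COC(=O)c1cc(O)ccc1OC(=O)COc1cc(O)c2c(=O)cc(-c3ccccc3)oc2c1` share a core and differ only in the group attached on an oxygen next to a carbonyl group. In a functional assay on cells (T-cell, Mus musculus, strain BALB/c) for inhibition, read by MTT assay, with a stated time of 72 h (on this read-out lower numbers stand for stronger inhibition and higher numbers for weaker inhibition), compound 1 gives 31100 nM, and compound 2 gives 29500 nM. The step of a 1.1-fold lower number from compound 1 to compound 2 (0.02 log units; within the scatter) is small, so the two numbers cannot be told apart; compound 2 stands simply alongside compound 1 rather than apart from it.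

Compound 3 `COC(=O)c1c(C)cccc1OC(=O)COc1cc(O)c2c(=O)cc(-c3ccccc3)oc2c1` is the next member. Compared with compound 2 it carries a group of 11 heavy atoms (9 carbon, 2 oxygen; one six-membered aromatic ring of carbon only) in place of a group of 11 heavy atoms (8 carbon, 3 oxygen; one six-membered aromatic ring of carbon only), on an oxygen next to a carbonyl group. The group that enters is of the same make-up as the group that compound 1 carries at the same place, only arranged differently on its ring. Within the data shown here, the only step in hand, the one from compound 1 to compound 2, exchanged groups of this kind at this oxygen without any change beyond the scatter. On that basis no step beyond the scatter is expected for compound 3, and the expected step is a 1.0-fold higher number from compound 2 to compound 3 (0.01 log units; within the scatter). Compound 3 is therefore estimated at 30000 nM in this assay, with a range from 15000 nM to 60000 nM.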

Compound 3, half-maximal inhibitory concentration: 37200 nM
The estimate for compound 3 lay 1.2-fold (0.09 log units) below the measured number, within the range that was stated.
By their numbers in this assay, from the lowest: compounds 2, 1 and 3 (each within the scatter of the next).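

Two groups of the same make-up, arranged differently on their ring, can now be compared at this oxygen, and this assay shows a 1.2-fold higher number from compound 1 to compound 3 (0.08 log units; within the scatter) with no difference that can be told from the scatter. The other new comparison shows a 1.3-fold higher number from compound 2 to compound 3 (0.10 log units; within the scatter) even though the group that enters has 0 hydrogen-bond donors and 2 hydrogen-bond acceptors, where the group that leaves has 1 hydrogen-bond donor and 3 hydrogen-bond acceptors, so among these three compounds that difference in counts goes with no readable change in the number. No supporting measurement is at hand that could explain why the three compounds stand so close together.

All three groups are closely related, each with one six-membered aromatic ring of carbon only, so these compounds do not show how far this position tolerates real change. Going by these compounds, it stays open whether a group of another kind on this oxygen, such as one carrying an amine or a carboxylic acid, or a longer chain with no ring at all, would move the number beyond the scatter.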